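Chloro and heteroaryl swaps on a shared pyridine-free core

The source may hold more compounds than are shown below. What is called first, only, known or untested is meant among the compounds shown, and "the series" means these compounds.

Measured compounds:
compound 1 `Oc1ccc(-c2cc(-c3ccc(Cl)cc3)nc(-c3cccs3)c2)cc1` 6450 nM
compound 2 `Oc1ccc(-c2cc(-c3cccc(Cl)c3)nc(-c3cccs3)c2)cc1` 5350 nM
compound 3 `Oc1ccc(-c2cc(-c3ccc(Cl)cc3)nc(-c3ccco3)c2)cc1` 6260 nM

Of the compounds shown here, three have been tested in a functional assay on T47D cells (Homo sapiens) for cytotoxicity, read by CCK-8 assay and cell counting, with a stated time of 2 days; on this read-out lower numbers stand for stronger inhibition and higher numbers for weaker inhibition; all three give numbers within the usual scatter of one another. The change 3-chlorophenyl in place of 4-chlorophenyl on an aromatic carbon gave a 1.2-fold lower number from compound 1 to compound 2 (0.08 log units; within the scatter). Compound 3 differs from compound 1 by furan-2-yl in place of thiophen-2-yl on an aromatic carbon, and compound 4 `Oc1ccc(-c2cc(-c3cccc(Cl)c3)nc(-c3ccco3)c2)cc1`, still to be measured in this assay, is related to compound 3 by 3-chlorophenyl in place of 4-chlorophenyl on an aromatic carbon. The change is the same kind of change as that from compound 1 to compound 2, but its surroundings differ: here the place is meta to a furan-2-yl group, whereas in the earlier pair it is meta to a thiophen-2-yl group. For compound 4 a step of a 1.2-fold lower number from compound 3 to compound 4 (0.07 log units; within the scatter) is expected, resting on a 1.2-fold lower number from compound 1 to compound 2 (0.08 log units; within the scatter). Compound 4 is therefore estimated at 5300 nM, between 2600 nM and 11000 nM.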

Compound 4, half-maximal inhibitory concentration: 5220 nM
For compound 4 the middle estimate is 1.0-fold (0.01 log units) above the measured one, within the range that was stated.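

In this assay, for the compounds shown here, 3-chlorophenyl in place of 4-chlorophenyl gave a 1.2-fold lower number from compound 3 to compound 4 (0.08 log units; within the scatter), matching the same change on the thiophen-2-yl core: the same change on two cores in this assay, a 1.2-fold lower number (0.08 log units; within the scatter) from compound 1 to compound 2 and a 1.2-fold lower number (0.08 log units; within the scatter) from compound 3 to compound 4, 1.0-fold (0.00 log units) apart, within the scatter of two such steps Furan-2-yl in place of thiophen-2-yl gave a 1.0-fold lower number from compound 2 to compound 4 (0.01 log units; within the scatter), and this change also read alike on both cores: the same change on two cores in this assay, a 1.0-fold lower number (0.01 log units; within the scatter) from compound 1 to compound 3 and a 1.0-fold lower number (0.01 log units; within the scatter) from compound 2 to compound 4, 1.0-fold (0.00 log units) apart, within the scatter of two such steps All of these steps lie within the scatter, so the agreement shows only that neither change gave a step beyond it on either core; it does not show that a step of clear size would carry from one core to another.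

As far as these compounds go, all four compounds keep the 4-hydroxyphenyl group, and what an amine or a carboxylic acid in place of its hydroxyl would give stays open. Also open, from the compounds shown here alone, is whether an amine or a longer chain in place of the chlorine would give a step beyond the scatter, and whether such a step would carry between the two cores.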